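Vero cytotoxicity notes: methoxy for methyl on the core

The compounds below may be only part of what the source reports. "The series", "measured", "known", "first", "only" and "open" are said of these compounds alone.

Measured compounds:
compound 1 `Cc1ccn2nc(C)c(C(=O)NCc3ccc(N4CCCCC4)cc3)c2c1`: > 100000 nM
compound 2 `Cc1nn2cccc(C)c2c1C(=O)NCc1ccc(N2CCC(c3ccc(OC(F)(F)F)cc3)CC2)cc1`: "not determined" (no result reported)

In an ADME assay on Vero cells (Chlorocebus sabaeus) for cytotoxicity, read by CCK-8 assay, with a stated time of 72 h (on this read-out lower numbers stand for stronger inhibition and higher numbers for weaker inhibition), compound 1 gives only a limit, > 100000 nM, not a number. Among the compounds with values here, compound 2 has no result in this assay, so it stands on no number at all; the one value is the limit (the limit of > 100000 nM in this assay, at which 1 of the 2 values shown sits). Compound 3 `COc1ccn2nc(C)c(C(=O)NCc3ccc(N4CCC(c5ccc(OC(F)(F)F)cc5)CC4)cc3)c2c1` differs from compound 2 by a group of 12 heavy atoms (9 carbon, 2 nitrogen, 1 oxygen; one five-membered aromatic ring with 2 hetero atoms, one six-membered aromatic ring with 1 hetero atom) in place of a group of 11 heavy atoms (9 carbon, 2 nitrogen; one five-membered aromatic ring with 2 hetero atoms, one six-membered aromatic ring with 1 hetero atom), on a carbonyl carbon, on a carbonyl carbon whose other neighbour is an amide-type nitrogen. Within the data shown here, with no measured step available, no shift beyond the usual scatter is expected from this change. Compound 3 is therefore expected to give about 100000 nM in this assay, most likely again reported only as a limit, within 30000 nM to 300000 nM.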

Compound 3, half-maximal inhibitory concentration: > 100000 nM
Compound 3: a limit, no number; the forecaster's own chance of this, stated with the estimate: 75%; the middle value lies on the limit itself.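

No new step can be read: compound 2 carries no number, compound 3 gives only a limit, and the pair allows no comparison. The compounds shown leave open how the change in the group on the carbonyl carbon shifts the read-out in this assay.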